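This account rests on a few compounds, and the source may have more. Where it says the series, first, only, none or still open, it means among the compounds named here.

Compound 1, `O=C(Nc1cccc(/C=C/C(=O)c2nc3ccccc3[nH]2)c1)c1ccccc1`: in a functional assay on 143B cells (Homo sapiens) for antiproliferative activity, read by MTT assay, with a stated time of 48 h (a higher number here means a weaker inhibitor, a lower number a stronger inhibitor), compound 1 gives 8340 nM.
Compound 2, `O=C(/C=C/c1cccc(NC(=O)c2ccccc2Br)c1)c1nc2ccccc2[nH]1`: in this assay compound 2 gives 6050 nM.
Compound 3, `COc1cccc(C(=O)Nc2cccc(/C=C/C(=O)c3nc4ccccc4[nH]3)c2)c1`: in this assay compound 3 gives 4610 nM.

Compound 3 has the lowest number of the three, but every gap to it is small: the step of a 1.8-fold lower number from compound 1 to compound 3 (0.26 log units; within the scatter) and the step of a 1.3-fold lower number from compound 2 to compound 3 (0.12 log units; within the scatter) both sit within the scatter, as does the step of a 1.4-fold lower number from compound 1 to compound 2 (0.14 log units; within the scatter). On these numbers the three compounds cannot be told apart, and compound 3 is not to be called the strongest of them.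

Compound 4, `Cc1ccccc1S(=O)(=O)Nc1cccc(/C=C/C(=O)c2nc3ccccc3[nH]2)c1`, is the next member. Its change from compound 3 is (2-methylphenyl)sulfonyl in place of (3-methoxyphenyl)carbonyl on a nitrogen on an aromatic ring. Among the compounds with values here, of the measured steps, only the one from compound 2 to compound 3 touches this part of the molecule, and it swapped the aryl group while the carbonyl stayed; the move to a sulfonyl has no measured parallel here. Every measured change on this side of the shared core stayed within the scatter, so a step of comparable size, in no settled direction, is expected in this assay. The estimated step from compound 3 to compound 4 is a 1.2-fold higher number from compound 3 to compound 4 (0.08 log units; within the scatter). Compound 4 is therefore expected to give about 5500 nM, between 1800 nM and 17000 nM.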

Compound 4, half-maximal inhibitory concentration: 4060 nM
Estimate against measurement, compound 4: 1.4-fold (0.13 log units) above, within the range that was stated.
By their numbers in this assay, from the lowest: compounds 4, 3, 2 and 1 (each within the scatter of the next, the first and the last beyond it).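

In this assay, a sulfonyl can stand on the nitrogen on an aromatic ring in place of a carbonyl without moving the number beyond the scatter from the two substituted amides: a 1.1-fold lower number from compound 3 to compound 4 (0.06 log units; within the scatter) and a 1.5-fold lower number from compound 2 to compound 4 (0.17 log units; within the scatter) leave compound 4 indistinguishable from both. Against the unsubstituted benzoyl, however, a 2.1-fold lower number from compound 1 to compound 4 (0.31 log units; beyond the scatter) is the first step in the series to pass the scatter, though only modestly, and that step changes the carbonyl to a sulfonyl and adds the methyl of the 2-methylphenyl group at the same time, so it cannot be assigned to either change alone. Nothing available explains these numbers or connects them to any property of the groups.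

Left open is how much of that modest step belongs to the sulfonyl itself, a question that a plain phenylsulfonyl on the same nitrogen would address. Also open, from the compounds shown here alone, is whether a different kind of group on that aromatic ring, such as an amine or a carboxylic acid, would move the number further than the methyl, methoxy and bromo groups seen so far.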